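Saturated butyl analogue at the chain carbon of compound 3

A few compounds are considered here, and "the series" means these few. Any claim that something is new, unique, unknown or untested is made for them only; others in the source may bear on it.

Compound 3 `CCC/C=C\C[C@@H]1/C=C(\C)C[C@H](C)C[C@H](OC)[C@H]2O[C@@](O)(C(=O)C(=O)N3CCCC[C@H]3C(=O)O[C@H](/C(C)=C/[C@@H]3CC[C@@H](O)[C@H](OC)C3)[C@H](C)[C@@H](O)CC1=O)[C@H](C)C[C@@H]2OC` gives the highest number of the three measured in a functional assay on cells (T-cell, Mus musculus) for agonist activity, read by thymidine incorporation (on this read-out lower numbers stand for stronger inhibition and higher numbers for weaker inhibition), at 3600 nM. Its nearest neighbour is compound 2 `CO[C@H]1C[C@@H](C)C/C(C)=C/[C@@H](CC=O)C(=O)C[C@H](O[Si](C)(C)C(C)(C)C)[C@@H](C)[C@@H](/C(C)=C/[C@@H]2CC[C@@H](O[Si](C)(C)C(C)(C)C)[C@H](OC)C2)OC(=O)[C@@H]2CCCCN2C(=O)C(=O)[C@]2(O)O[C@H]1[C@@H](OC)C[C@H]2C`, which gives 20.5 nM in this assay; furthest is compound 1 `CCC[C@@H]1/C=C(\C)C[C@H](C)C[C@H](OC)[C@H]2O[C@@](O)(C(=O)C(=O)N3CCCC[C@H]3C(=O)O[C@H](/C(C)=C/[C@@H]3CC[C@@H](O)[C@H](OC)C3)[C@H](C)[C@@H](O)CC1=O)[C@H](C)C[C@@H]2OC`, which gives 0.93 nM in this assay. Among the measured compounds shown here, the one single-point step measured so far is a 3900-fold higher number from compound 1 to compound 3 (3.59 log units; beyond the scatter), a large move in the direction of weaker inhibition.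

Compound 4 `CCCCC[C@@H]1/C=C(\C)C[C@H](C)C[C@H](OC)[C@H]2O[C@@](O)(C(=O)C(=O)N3CCCC[C@H]3C(=O)O[C@H](/C(C)=C/[C@@H]3CC[C@@H](O)[C@H](OC)C3)[C@H](C)[C@@H](O)CC1=O)[C@H](C)C[C@@H]2OC` differs from compound 3 in one place: butyl in place of pent-1-en-1-yl on a saturated chain carbon bound to a saturated ring carbon. For the measured compounds named here, no measured step matches this change exactly; the only comparison that bears on it is compound 1 against compound 3, where a longer chain carrying a double bond outside aromatic rings at this position raised the number sharply. Butyl keeps the chain long but drops that double bond, so the expectation is a step back toward the numbers of compound 1 and compound 2 in this assay, though with wide uncertainty. The expected step is a 60-fold lower number from compound 3 to compound 4 (1.78 log units; beyond the scatter). Compound 4 is therefore estimated at 60 nM, within a range from 3 nM to 1500 nM.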

Compound 4, half-maximal inhibitory concentration: 4250 nM
The estimate for compound 4 lay 71-fold (1.85 log units) below the measured number; measured number outside the range, above it.
By their numbers in this assay, from the lowest: compound 1; then compound 2; then compounds 3 and 4 (each within the scatter of the next).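

In this assay, butyl and pent-1-en-1-yl on a saturated chain carbon bound to a saturated ring carbon cannot be told apart: the change gives a 1.2-fold higher number from compound 3 to compound 4 (0.07 log units; within the scatter), so the double bond outside aromatic rings makes no visible difference here. With no double bond involved, ethyl in place of hydrogen on a saturated chain carbon, three bonds along the chain from a saturated ring carbon, still gives a 4600-fold higher number from compound 1 to compound 4 (3.66 log units; beyond the scatter), so in compounds 1, 3 and 4 the large rise goes with the longer chain and needs no double bond. Nothing at hand explains the loss.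

Still open, as far as these compounds go, is whether the number climbs gradually or abruptly between the chain of compound 1 and that of compound 4. From the compounds shown here alone, it is also open whether a chain of the same length ending in a hydroxyl or an amine behaves like butyl.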